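The compounds below may be only part of what the source reports. "The series", "measured", "known", "first", "only" and "open" are said of these compounds alone.

Working notes on the shared core of this series. Compound 1 `COc1ccccc1/C=C1\CCC/C(=C\c2cccc(OC)c2OC)C1=O` gives 12000 nM in a functional assay on MCF7 cells (Homo sapiens) for cytotoxicity, read by MTT assay, with a stated time of 72 h; on this read-out lower numbers stand for stronger inhibition and higher numbers for weaker inhibition. Compound 2 `COc1cccc(/C=C2\CCC/C(=C\c3ccc(O)cc3)C2=O)c1OC` returns only a limit in this assay, > 20000 nM. Among the compounds with values here, compound 2 thus stands at the limit of the read-out, (the limit of > 20000 nM in this assay, at which 1 of the 2 values shown sits), and the single measured step, an at least 1.6-fold higher number from compound 1 to compound 2 (0.22 log units; that floor lies within the scatter), comes with 4-hydroxyphenyl in place of 2-methoxyphenyl on a double-bonded chain carbon bound to a double-bonded ring carbon. Compound 3 `COc1cccc(/C=C2\CCC/C(=C\c3ccc(O)c(O)c3)C2=O)c1OC` differs from compound 2 by hydroxy in place of hydrogen on an aromatic carbon, which read one bond further out is 4-hydroxyphenyl to 3,4-dihydroxyphenyl. Within the data shown here, no measured step touches this position, and the one step available starts from a numbered value and ends at a limit, so it gives only a loose bound. Compound 3 is therefore expected to stay near the limit in this assay, with a step that the limit leaves unreadable from compound 2 to compound 3 meaning no step beyond the scatter. The estimate for compound 3 in this assay is 25000 nM, within 8000 nM to 70000 nM.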

Compound 3, half-maximal inhibitory concentration: 4700 nM
For compound 3 the middle estimate is 5.3-fold (0.73 log units) above the measured one, outside the stated range (below it).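

In this assay, within the data shown here, the change to 3,4-dihydroxyphenyl brings an at least 4.2-fold lower number from compound 2 to compound 3 (0.62 log units; beyond the scatter), the first step at this position that lies beyond the scatter, and it runs towards stronger inhibition. That size is only a floor, because compound 2 carries a limit and not a number: the limit of > 20000 nM in this assay, at which 1 of the 3 values shown sits. The same group also sets compound 3 apart from compound 1, with a 2.6-fold lower number from compound 1 to compound 3 (0.41 log units; beyond the scatter), whereas the 4-hydroxyphenyl step from compound 1 gave only a floor within the scatter.

Hydroxy is the only group shown on this aromatic carbon, so it stays open whether an amino group or a fluorine there would give a like step. Also open, going by these compounds, is whether the step holds when the other aryl group of the shared core changes.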